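The source may report more compounds than this note shows. Statements on the series, on what has been measured and on what is new or still open speak of the compounds shown alone.

In a functional assay on cells (Renal cancer cell line, Homo sapiens) for cytotoxicity, read by sulforhodamine B assay, with a stated time of 48 h (a lower number here means a stronger inhibitor of growth, a higher number a weaker inhibitor of growth), two compounds with a shared core have been measured so far. Compound 1 (`COc1cc2c(cc1C)NC(=O)/C2=C/c1c(OC)nc2sc(C)cn12`) gives 5810 nM, and compound 2 (`COc1ccc2c(c1)/C(=C\c1c(OC)nc3sc(C)cn13)C(=O)N2`) gives 650 nM, the lower of the two numbers and so the stronger growth inhibitor of the pair. Compound 3 (`COc1nc2sc(C)cn2c1/C=C1/C(=O)Nc2ccccc21`) has not yet been measured. It differs from compound 2 in one place: hydrogen in place of methoxy on an aromatic carbon. In plain words, hydrogen takes the place of methoxy on an aromatic carbon.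

For the measured compounds named here, only one measured step bears on this change, and only loosely: an 8.9-fold lower number from compound 1 to compound 2 (0.95 log units; beyond the scatter), where hydrogen took the place of methyl on an aromatic carbon. That step was modest but beyond the usual scatter, so swapping a group for hydrogen can clearly move the number in this assay. However, methyl is not methoxy, and no measured pair shows methoxy being lost, so the direction of that step cannot simply be carried over. No clear change beyond the scatter is therefore expected, and the estimated step is a 1.2-fold higher number from compound 2 to compound 3 (0.09 log units; within the scatter). For compound 3 the estimated value is 800 nM, with an expected range from 200 nM to 3000 nM.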

Compound 3, concentration for 50% growth inhibition: 3530 nM
For compound 3 the middle estimate is 4.4-fold (0.64 log units) below the measured one; measured number above the stated range.
By their numbers in this assay, from the lowest: compound 2; then compounds 3 and 1 (each within the scatter of the next).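

In this assay, taking the methoxy off this aromatic carbon and leaving hydrogen gives a 5.4-fold higher number from compound 2 to compound 3 (0.73 log units; beyond the scatter) and so weakens growth inhibition, a loss that is modest but clear. Methoxy at this place therefore counts for something in this pair, which the earlier compounds could not show because neither of them had hydrogen here. Set beside the earlier change, where hydrogen replaced methyl and gave an 8.9-fold lower number from compound 1 to compound 2 (0.95 log units; beyond the scatter), this step runs the opposite way, so putting hydrogen in place of a group on this six-membered aromatic ring does not move the number in a single direction across these compounds.

On these data alone, with only methoxy and hydrogen compared at this carbon, it remains open whether a hydroxyl group, an amine, a fluorine atom or a longer ether such as ethoxy would keep the stronger number of compound 2 or lose it. As far as these compounds go, it is also open whether this gain from methoxy would hold with other groups elsewhere on the shared core. No measurement given here accounts for why the number rises when the methoxy is lost.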